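The source may report more compounds than this note shows. Statements on the series, on what has been measured and on what is new or still open speak of the compounds shown alone.

Measured so far:
compound 1 `CCN(Cc1ccc(F)cc1)Cc1nn(-c2ccccc2F)c2c1CCS(=O)(=O)O2` — 0.6%
compound 2 `CCN(Cc1ccc(Br)cc1)Cc1nn(-c2ccccc2F)c2c1CCS(=O)(=O)O2` — 12.9%
compound 3 `CCN(Cc1ccc(Cl)cc1)Cc1nn(-c2ccccc2F)c2c1CCS(=O)(=O)O2` — 4.2%

In a functional assay, with a stated time of 2 h, tested at 100 uM (a lower number here means less inhibition, a higher number more inhibition at the concentration tested (going by the name of the read-out)), compound 2 holds the largest of the three numbers, but the separation from compound 3, a number 8.7 percentage points lower from compound 2 to compound 3 (within the scatter), lies within the scatter; only the separation from compound 1, a number 12.3 percentage points higher from compound 1 to compound 2 (beyond the scatter), lies beyond it. The remaining step, a number 3.6 percentage points higher from compound 1 to compound 3 (within the scatter), is also within the scatter.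

Compound 4 `CN(Cc1ccc(Br)cc1)Cc1nn(-c2ccccc2F)c2c1CCS(=O)(=O)O2` differs from compound 2 by hydrogen in place of methyl on a saturated chain carbon bound to an amine nitrogen. Going by the values given here, none of the measured steps concerns this position; all three exchange a halogen on an aromatic carbon, so they give no direct guide to the size or direction of this change. Among the compounds with values here, with no relevant precedent, no step beyond the scatter is expected in this assay.

Compound 4 is therefore estimated at 10%, range 2% to 22%, which means an expected step of a number 2.9 percentage points lower from compound 2 to compound 4 (within the scatter).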

Compound 4, a percentage reported as inhibition, at one concentration (the size of the read-out at that concentration, not a potency): 0.2%
Compound 4: the middle estimate sits 9.8 percentage points above what was measured, outside the stated range (below it).
By their numbers in this assay, from the lowest: compounds 4, 1, 3 and 2 (each within the scatter of the next, the first and the last beyond it).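

In this assay, ethyl to methyl at this position gives a number 12.7 percentage points lower from compound 2 to compound 4 (beyond the scatter) and so removes most of the read-out that compound 2 carries. The earlier compounds shown here showed a step beyond the scatter only from a halogen exchange on an aromatic carbon; this change shows that the group on the amine nitrogen also matters. Nothing at hand explains the step.

From the compounds shown here alone, whether the same change would read alike with fluoro or chloro in place of bromo remains open. So does the reading of a propyl chain, a cyclopropyl group or a hydrogen at this position.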